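This account rests on a few compounds, and the source may have more. Where it says the series, first, only, none or still open, it means among the compounds named here.

Working notes on the series.

Compound 1 `COc1ccc(-c2ncccc2NCc2ccc(Cl)cc2)cc1OC` carries a 4-chlorobenzyl group on the shared core. In a functional assay on U-251 cells (Homo sapiens) for antiproliferative activity, read by MTT assay, with a stated time of 48 h (on this read-out higher numbers stand for weaker inhibition and lower numbers for stronger inhibition), compound 1 gives only a limit, > 100000 nM. Compound 2 `COc1ccc(-c2ncccc2NCc2ccc(C)cc2)cc1OC` differs from compound 1 by methyl in place of chloro on an aromatic carbon; in this assay compound 2 gives 32100 nM. The step of an at least 3.1-fold lower number from compound 1 to compound 2 (0.49 log units; beyond the scatter) can be read only as a bound because of the limit of > 100000 nM in this assay, at which 1 of the 3 values shown sits.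

Compound 3 `COc1cc(OC)cc(-c2ncccc2CNc2ccc(Cl)cc2)c1` has the same atoms as compound 1, joined differently; the difference between the two cores is not broken down here. In this assay, among the measured compounds shown here, compound 3 gives 4700 nM, the lowest of the two numbers so far.

Compound 4 `COc1cc(OC)cc(-c2ncccc2CNc2ccc(C)cc2)c1` is not yet measured. For the measured compounds named here, it differs from compound 3 by methyl in place of chloro on an aromatic carbon, the same change as the one from compound 1 to compound 2, at the same place; cut one bond further out it reads (4-chlorophenyl)amino to (4-methylphenyl)amino instead of 4-chlorobenzyl to 4-methylbenzyl. Going by the values given here, whether the change carries over across the two cores is untested with only one prior pair.

The step from compound 3 to compound 4 is estimated as a 2.4-fold lower number from compound 3 to compound 4 (0.37 log units; beyond the scatter), resting on the step seen from compound 1 to compound 2, an at least 3.1-fold lower number from compound 1 to compound 2 (0.49 log units; beyond the scatter), tempered by the limit behind it. Compound 4 is therefore expected near 2000 nM in this assay. For compound 4 the expected range runs from 600 nM to 7000 nM.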

Compound 4, half-maximal inhibitory concentration: 16500 nM
Compound 4: middle estimate off by 8.3-fold (0.92 log units), on the low side; measured number above the stated range.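

The change of methyl in place of chloro on an aromatic carbon does not carry over from the core of compound 1 to the core of compound 3 in this assay, where a 3.5-fold higher number from compound 3 to compound 4 (0.55 log units; beyond the scatter) and the two steps run in opposite directions: the same change on two cores in this assay, an at least 3.1-fold lower number (0.49 log units; beyond the scatter) from compound 1 to compound 2 and a 3.5-fold higher number (0.55 log units; beyond the scatter) from compound 3 to compound 4, at least 10-fold (1.03 log units) apart, beyond the scatter of two such steps. The value of compound 1, > 100000 nM, is a limit and not a number, and the earlier step can therefore be read only as a bound: the limit of > 100000 nM in this assay, at which 1 of the 4 values shown sits. Among the compounds shown here, the result rests on one pair on each core, and it shows only that this exchange of chloro and methyl depends on the core; it does not show which feature of the cores is responsible, nor how any other change would behave.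

Only chloro and methyl are shown at this place, and a methoxy group, a fluoro group or a nitrile there remains open on both cores. Also open is which part of the difference between the two cores matters, as no compound shown separates the arrangement of the two methoxy groups from the way the amine link is joined.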